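Compound 3: chloro in place of fluoro, expected potency

The source may hold more compounds than are shown below. What is called first, only, known or untested is meant among the compounds shown, and "the series" means these compounds.

Among the compounds with values here, compound 2 `O=S(=O)(c1cccc(F)c1)c1cn(C2CCNC2)c2ccccc12` and compound 1 `O=S(=O)(c1ccccc1)c1cn(C2CCNC2)c2ccccc12` are the only members measured so far. In a functional assay on HeLa cells for agonist activity at 5-hydroxytryptamine receptor 6 (Homo sapiens), read by cAMP accumulation and immunoassay, with a stated time of 10 min (a lower number here means that less compound is needed, a higher number that more compound is needed for the effect), compound 2 gives 68 nM, and compound 1 gives 60 nM; the two figures are not separated beyond the scatter, so compound 2 stands level with compound 1 rather than apart from it. Within the data shown here, the only measured step is a 1.1-fold higher number from compound 1 to compound 2 (0.05 log units; within the scatter), which concerns the same aromatic carbon that is now changed again.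

Compound 3 `O=S(=O)(c1cccc(Cl)c1)c1cn(C2CCNC2)c2ccccc12` differs from compound 2 by chloro in place of fluoro on an aromatic carbon. Among the measured compounds shown here, no measured pair shows fluoro giving way to chloro, so the step of a 1.1-fold higher number from compound 1 to compound 2 (0.05 log units; within the scatter) is the only one that bears on this position, and it was flat. On that basis the step of a 1.0-fold higher number from compound 2 to compound 3 (0.01 log units; within the scatter) is expected to stay small in this assay, with no direction beyond the scatter that the data would support. Compound 3 is therefore estimated at 70 nM in this assay, with a range from 25 nM to 200 nM.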

Compound 3, half-maximal effective concentration: 125 nM
The estimate for compound 3 lay 1.8-fold (0.25 log units) below the measured number, within the range that was stated.
By their numbers in this assay, from the lowest: compounds 1, 2 and 3 (each within the scatter of the next, the first and the last beyond it).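

In this assay, within the data shown here, chloro gives the first step on this aromatic carbon that lies beyond the scatter: a 2.1-fold higher number from compound 1 to compound 3 (0.32 log units; beyond the scatter), a modest one, and in the direction of more compound being needed. The exchange of one halogen for the other, a 1.8-fold higher number from compound 2 to compound 3 (0.26 log units; within the scatter), stays within the scatter, so the data do not separate chloro from fluoro here, and the 3-chlorophenyl and 3-fluorophenyl compounds stand level with each other. The position therefore shows some response to substitution, but only against hydrogen and only with chloro, and no measurement on hand bears on what lies behind that step.

Open, on these data alone, is whether the modest step seen with chloro grows with a larger group on the same carbon, such as bromo, methyl, trifluoromethyl or methoxy, or changes with an amine or a carboxylic acid there. Also open, as far as these compounds go, is whether chloro on another carbon of this six-membered aromatic ring gives a step of similar size, and whether the same exchange holds with a different group in place of the shared core's saturated amine ring.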